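The source may report more compounds than this note shows. Statements on the series, on what has been measured and on what is new or still open speak of the compounds shown alone.

Measured compounds:
compound 1, `CCc1cccc(-c2ccc(C(=O)NC(/C=C/c3ccccc3)C(Cc3cccc(C(=N)N)c3)C(=O)OC)cc2)c1`: 2600 nM
compound 2, `COC(=O)C(Cc1cccc(C(=N)N)c1)C(/C=C/c1ccccc1)NC(=O)c1ccc(-c2ccc(OC)cc2OC)cc1`: 2900 nM

Among the compounds with values here, in an assay on isolated protein (Oryctolagus cuniculus) for inhibition of Trypsin (Homo sapiens) (a higher number here means a weaker inhibitor, a lower number a stronger inhibitor), compound 1 gives 2600 nM, the lowest of the two numbers, but its only neighbour, compound 2, stands a step of a 1.1-fold higher number from compound 1 to compound 2 (0.05 log units; within the scatter) away, so the two cannot be ordered. That single measured step, in which a 2,4-dimethoxyphenyl took the place of a 3-ethylphenyl, is the only one that touches the same part of the shared core.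

Compound 3, `CCOc1cccc(-c2ccc(C(=O)NC(/C=C/c3ccccc3)C(Cc3cccc(C(=N)N)c3)C(=O)OC)cc2)c1`, has not yet been measured. It differs from compound 1 by ethoxy in place of ethyl on an aromatic carbon, on an aromatic carbon of a six-membered aromatic ring of carbon only. Within the data shown here, the one related step, from compound 1 to compound 2, stayed within the scatter, and the change here is smaller, so no step beyond the scatter is expected. The expected step is no change at the digits printed from compound 1 to compound 3 (within the scatter). For compound 3 the expected value is 2600 nM, with a range from 1300 nM to 5200 nM.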

Compound 3, half-maximal inhibitory concentration: 3600 nM
The estimate for compound 3 lay 1.4-fold (0.14 log units) below the measured number; low and high end bracket the measured number.
By their numbers in this assay, from the lowest: compounds 1, 2 and 3 (each within the scatter of the next).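

In this assay, ethoxy in place of ethyl at this position, meta to a large group, gives a 1.4-fold higher number from compound 1 to compound 3 (0.14 log units; within the scatter) and so adds a hydrogen-bond acceptor to the group without a readable change. The second new comparison, a 1.2-fold higher number from compound 2 to compound 3 (0.09 log units; within the scatter), also stays within the scatter, so the 3-ethylphenyl, 3-ethoxyphenyl and 2,4-dimethoxyphenyl compounds cannot be ordered and none of these three groups stands apart from the others. No supporting evidence bears on this result.

As far as these compounds go, it remains open whether an amine, a carboxylic acid or a longer chain such as propoxy on this aromatic carbon would move the number beyond the scatter. From the compounds shown here alone, it also remains open how changes elsewhere on the shared core would affect the number, as these three compounds differ only in this one group.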